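The source may report more compounds than this note shows. Statements on the series, on what has been measured and on what is new or still open speak of the compounds shown alone.

Compound 3 `Cc1ccc2ncc(S(=O)(=O)c3cc(F)cc(F)c3)c(N3CCC(C)CC3)c2c1` stands lowest of the three compounds measured in an assay on isolated protein for displacement of a labelled ligand from metabotropic glutamate receptor 5 (Homo sapiens), with a stated time of 60 min, tested at 1 uM (on this read-out lower numbers stand for less inhibition and higher numbers for more inhibition at the one concentration tested (going by the name of the read-out)), where compound 3 gives 72%. Its nearest neighbour is compound 2 `Cc1ccc2ncc(S(=O)(=O)c3cc(Cl)cc(Cl)c3)c(N3CCC(C)CC3)c2c1`, which in this assay gives 75%, a step of a number 3 percentage points lower from compound 2 to compound 3 (within the scatter). Furthest away is compound 1 `Cc1ccc2ncc(S(=O)(=O)c3ccc(F)cc3)c(N3CCC(C)CC3)c2c1`, which in this assay gives 90%; the steps of a number 18 percentage points lower from compound 1 to compound 3 (beyond the scatter) and a number 15 percentage points lower from compound 1 to compound 2 (beyond the scatter) both lie beyond the scatter. Compound 4 `Cc1ccc2ncc(S(=O)(=O)c3ccc(C)c(Cl)c3)c(N3CCC(C)CC3)c2c1` differs from compound 3 by 3-chloro-4-methylphenyl in place of 3,5-difluorophenyl on a sulfonyl sulfur. Going by the values given here, no measured step matches this change directly: the halogen swap a number 3 percentage points lower from compound 2 to compound 3 (within the scatter) stayed within the scatter, while moving from 4-fluorophenyl to either 3,5-dihalophenyl cost a modest amount. Compound 4 is therefore expected to land between those cases, at 80% with a range of 65% to 92%, an estimated step of a number 8 percentage points higher from compound 3 to compound 4 (within the scatter).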

Compound 4, a percentage reported as inhibition, at one concentration (the size of the read-out at that concentration, not a potency): 91%
For compound 4 the middle estimate is 11 percentage points below the measured one, within the range that was stated.
By their numbers in this assay, from the lowest: compounds 3 and 2 (each within the scatter of the next); then compounds 1 and 4 (each within the scatter of the next).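

In this assay, the 3,5-dihalophenyl groups turn out not to set the level for every disubstituted ring on this sulfonyl sulfur: 3-chloro-4-methylphenyl gives a number 19 percentage points higher from compound 3 to compound 4 (beyond the scatter) and a number 16 percentage points higher from compound 2 to compound 4 (beyond the scatter). Against 4-fluorophenyl, the same group gives a number 1 percentage points higher from compound 1 to compound 4 (within the scatter), so a chlorine on the ring does not by itself go with the lower numbers. Nothing available explains this difference. The compounds shown leave open whether 3-chlorophenyl or 4-methylphenyl alone would match 3-chloro-4-methylphenyl. Going by these compounds, how a 4-methoxyphenyl or a pyridine ring would read here also remains open.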